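The source may report more compounds than this note shows. Statements on the series, on what has been measured and on what is new or still open speak of the compounds shown alone.

Measured so far in an assay on isolated protein for inhibition of Rho-associated protein kinase 1 (Homo sapiens), read by scintillation counting, radiometric assay and 33P incorporation, with a stated time of 40 min, in the presence of a further agent that is not named here; on this read-out higher numbers stand for weaker inhibition and lower numbers for stronger inhibition:
compound 1 `COc1cc(OCC(=O)Nc2cccc(NC(=O)c3ccc(N(C)C)cc3)c2)ccc1C=O` gives 3740 nM;
compound 3 `CCCc1ccc(C(=O)Nc2cccc(NC(=O)COc3ccc4c(=O)ccoc4c3)c2)cc1` gives 143 nM.
Compound 2 `Cc1coc2cc(OCC(=O)Nc3cccc(NC(=O)c4ccc(N(C)C)cc4)c3)ccc2c1=O` sits at a limit of the measurement rather than a number, > 10000 nM.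

Compound 3 holds the lowest of the two numbers and is therefore the stronger inhibitor of the pair, with compound 1 clearly higher, beyond the usual scatter. One of the three values is only a limit (the limit of > 10000 nM in this assay, at which 1 of the 3 values shown sits).

Compound 4 `O=C(COc1ccc2c(=O)ccoc2c1)Nc1cccc(NC(=O)c2cccc([N+](=O)[O-])c2)c1` is not yet measured. It differs from compound 3 in one place: 3-nitrophenyl in place of 4-propylphenyl on a carbonyl carbon. Among the compounds with values here, no measured pair shows this same change, so the expectation rests on the change alone. The expected step is a 3.1-fold higher number from compound 3 to compound 4 (0.50 log units; beyond the scatter), toward weaker inhibition, modest but likely beyond the scatter. For compound 4 in this assay the estimate is 450 nM, within a range from 110 nM to 2000 nM.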

Compound 4, half-maximal inhibitory concentration: 528 nM
The estimate for compound 4 lay 1.2-fold (0.07 log units) below the measured number; the range from low to high includes it.
By their numbers in this assay, from the lowest: compound 3; then compound 4; then compound 1. At a limit, above all of these: compound 2.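

Placing 3-nitrophenyl instead of 4-propylphenyl on the carbonyl carbon in this assay gives a 3.7-fold higher number from compound 3 to compound 4 (0.57 log units; beyond the scatter), the first reading of a change at this position. Both groups are six-membered aromatic rings of carbon only, so the step comes from what the ring carries and where it carries it. Nothing measured here accounts for the step.

From the compounds shown here alone, whether losing the propyl chain or gaining the nitro group matters more remains open. How a carboxylic acid or a butyl chain on that ring would read is also unknown.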